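This account rests on a few compounds, and the source may have more. Where it says the series, first, only, none or still open, it means among the compounds named here.

Of the compounds shown here, three that share one core have been tested in a functional assay on MDA-MB-231 cells (Homo sapiens) for antiproliferative activity, read by CCK-8 assay, with a stated time of 72 h; on this read-out lower numbers stand for stronger inhibition and higher numbers for weaker inhibition. Compound 1 `CC1=NN(c2ccc(Br)cc2)C(=O)C12C=CC(=O)C=C2c1cccc(C)c1` gives 2890 nM, compound 2 `CC1=NN(c2ccc(C)cc2)C(=O)C12C=CC(=O)C=C2c1ccc(C)cc1` gives 5110 nM, and compound 3 `CC1=NN(c2cccc(Cl)c2)C(=O)C12C=CC(=O)C=C2c1ccc(C)cc1` gives 3820 nM. On these numbers compound 3 stands second highest of the three, with compound 1 nearest and compound 2 furthest, and both of those gaps lie within the usual scatter. Compound 4 `CC1=NN(c2ccc(Br)cc2)C(=O)C12C=CC(=O)C=C2c1ccc(C)cc1` is compound 3 with a single change: 4-bromophenyl in place of 3-chlorophenyl on an amide-type nitrogen in a ring. Within the data shown here, only one measured step touches the same position, a 1.3-fold lower number from compound 2 to compound 3 (0.13 log units; within the scatter), and it stayed within the scatter. Compound 1 also carries 4-bromophenyl on an amide-type nitrogen in a ring, but it differs from compound 4 in a second place as well, so its number can serve only as a rough guide. The step of a 1.2-fold lower number from compound 3 to compound 4 (0.08 log units; within the scatter) is therefore expected to be small, with no clear direction beyond the scatter. Compound 4 is expected to give about 3200 nM in this assay, most likely between 1500 nM and 6800 nM.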

Compound 4, half-maximal inhibitory concentration: 15900 nM
Compound 4: middle estimate off by 5.0-fold (0.70 log units), on the low side; the whole stated range lies below it.
By their numbers in this assay, from the lowest: compounds 1, 3 and 2 (each within the scatter of the next); then compound 4.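

In this assay, the group on the amide-type nitrogen proved able to move the number: the earlier change there gave only a 1.3-fold lower number from compound 2 to compound 3 (0.13 log units; within the scatter), whereas 4-bromophenyl in place of 3-chlorophenyl gives a 4.2-fold higher number from compound 3 to compound 4 (0.62 log units; beyond the scatter). Bromo in place of methyl on that same phenyl ring gives a 3.1-fold higher number from compound 2 to compound 4 (0.49 log units; beyond the scatter), so this step too goes beyond the scatter. The 4-bromophenyl group alone does not fix the number, since with it held constant, 4-methylphenyl in place of 3-methylphenyl on a double-bonded ring carbon gives a 5.5-fold higher number from compound 1 to compound 4 (0.74 log units; beyond the scatter).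

Nothing available explains these steps. The step from 3-chlorophenyl to 4-bromophenyl changes both the halogen and its printed ring number. 4-Chlorophenyl and 3-bromophenyl would be needed to separate the two, and an amine or a carboxylic acid on this ring remains untested among the compounds shown.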